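Dimethylphenyl in Place of Iodophenyl on the Sulfonamide

The source may hold more compounds than are shown below. What is called first, only, known or untested is meant among the compounds shown, and "the series" means these compounds.

Three compounds have been measured in a functional assay on M21 cells (Homo sapiens) for antiproliferative activity, read by sulforhodamine B assay, with a stated time of 48 h; on this read-out lower numbers stand for stronger inhibition and higher numbers for weaker inhibition:
Compound 1, `CCCCOc1ccc(NS(=O)(=O)c2ccc(N3CCNC3=O)cc2)cc1`: 580 nM
Compound 2, `O=C1NCCN1c1ccc(S(=O)(=O)Nc2ccc(I)cc2)cc1`: 260 nM
Compound 3, `CC(C)(C)c1ccc(NS(=O)(=O)c2ccc(N3CCNC3=O)cc2)cc1`: a limit, > 1000 nM

Compound 2 gives the lowest of the two numbers; the nearest is a 2.2-fold lower number from compound 1 to compound 2 (0.35 log units; beyond the scatter). For compound 3 only a limit is known (the limit of > 1000 nM in this assay, at which 1 of the 3 values shown sits). Compound 4, `Cc1ccc(NS(=O)(=O)c2ccc(N3CCNC3=O)cc2)cc1C`, is not yet measured. Its change from compound 2: 3,4-dimethylphenyl in place of 4-iodophenyl on a sulfonamide nitrogen. Among the compounds with values here, no measured step makes exactly this change. The closest are an at least 3.8-fold higher number from compound 2 to compound 3 (0.58 log units; beyond the scatter) and, in reverse, a 2.2-fold lower number from compound 1 to compound 2 (0.35 log units; beyond the scatter), both showing higher numbers when the iodo is replaced. A rise is therefore expected. Compound 4 is estimated at 700 nM (range 300 nM to 1800 nM). That amounts to an expected 2.7-fold higher number from compound 2 to compound 4 (0.43 log units; beyond the scatter).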

Compound 4, half-maximal inhibitory concentration: 94 nM
Compound 4: middle estimate off by 7.4-fold (0.87 log units), on the high side; the whole stated range lies above it.
By their numbers in this assay, from the lowest: compound 4; then compound 2; then compound 1. At a limit, above all of these: compound 3.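

In this assay, 3,4-dimethylphenyl in place of 4-iodophenyl on the sulfonamide nitrogen gives a 2.8-fold lower number from compound 2 to compound 4 (0.44 log units; beyond the scatter). Replacing the iodo therefore does not always raise the number, as compound 1 and compound 3 had suggested, and iodine is not needed for a low value at this position. What counts is which group enters, not simply the loss of the iodo.

Going by these compounds, how much each methyl contributes stays open, as does whether an amine or a carboxylic acid on this ring would fit. Compound 3 remains a limit rather than a number: the limit of > 1000 nM in this assay, at which 1 of the 4 values shown sits.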